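Acetyl to hydrogen on the side-chain oxygen

The source may report more compounds than this note shows. Statements on the series, on what has been measured and on what is new or still open speak of the compounds shown alone.

Compound 1 `CC(=O)OC(C)n1cnc2c(Cl)nc(I)nc21` carries the acetoxy side chain; in a functional assay on HeLa cells (Homo sapiens) for inhibition (on this read-out lower numbers stand for stronger inhibition and higher numbers for weaker inhibition), compound 1 gives 5130 nM. Compound 2 `CC(O)n1cnc2c(Cl)nc(I)nc21` differs from it by hydrogen in place of acetyl on an oxygen on a saturated carbon. In this assay compound 2 reaches only the limit of the read-out, > 500000 nM, and not a number. The step is an at least 97-fold higher number from compound 1 to compound 2 (1.98 log units; beyond the scatter). Compound 3 `CC(=O)OC(C)n1cnc2c(S)nc(F)nc21` shares the acetoxy side chain of compound 1; the difference between the two cores is not broken down here. In this assay compound 3 also sits at the limit, > 500000 nM, not at a number. Compound 4 `CC(O)n1cnc2c(S)nc(F)nc21`, not yet measured, differs from compound 3 by hydrogen in place of acetyl on an oxygen on a saturated carbon; this is the same change as that from compound 1 to compound 2, at the same place. Note that the limit of > 500000 nM in this assay, at which 2 of the 3 values shown sit, is a limit rather than a value. For compound 4 in this assay a step like a step that the limit leaves unreadable from compound 3 to compound 4 is expected, since the earlier one was an at least 97-fold higher number from compound 1 to compound 2 (1.98 log units; beyond the scatter) and compound 3 already stands at the limit. Compound 4 is therefore expected to give 1000000 nM, most likely reported only as a limit, between 500000 nM and 5000000 nM.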

Compound 4, half-maximal inhibitory concentration: > 500000 nM
Compound 4: a limit, no number (the forecaster's own chance of this, stated with the estimate: 95%); the middle value does not contradict the limit.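

In this assay the change from acetoxy to hydroxy gives no readable step between compound 3 and compound 4, because both stand at a limit and not at a number: the limit of > 500000 nM in this assay, at which 3 of the 4 values shown sit.

The compounds shown leave open what numbers lie behind these limits, and whether this change has any effect on the core of compound 3.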